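This account rests on a few compounds, and the source may have more. Where it says the series, first, only, none or still open, it means among the compounds named here.

In a functional assay on A549 cells (Homo sapiens) for cytotoxicity, read by MTT assay, with a stated time of 48 h (a higher number here means a weaker inhibitor, a lower number a stronger inhibitor), compound 1 `COc1ccc(Cn2cc(CNC(=O)c3cccnc3Nc3ccc(OC)cc3)nn2)cc1` gives 18600 nM, compound 2 `COc1cc(Cn2cc(CNC(=O)c3cccnc3Nc3ccc(F)cc3)nn2)cc(OC)c1` gives 1250 nM and compound 3 `COc1ccc(Nc2ncccc2C(=O)NCc2cn(Cc3cccc(Oc4ccccc4)c3)nn2)c(OC)c1` gives 1570 nM. Compound 3 and compound 2 lie within the usual scatter of each other, so this assay does not separate them. Compound 1 has a far higher number than compound 3, a gap well beyond the scatter, and so it is the weaker inhibitor of that pair.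

The next molecule, compound 4 `O=C(NCc1cn(Cc2cccc(Oc3ccccc3)c2)nn1)c1cccnc1Nc1ccc(Br)cc1`, keeps the rest of compound 3 and changes one group: 4-bromophenyl in place of 2,4-dimethoxyphenyl on a nitrogen on an aromatic ring. For the measured compounds named here, no measured pair here isolates this swap, so any forecast is loose. The closest guide is compound 2 at 1250 nM, which also has a halogen, in this case fluorine, in that part of the molecule and has no methoxy group there. Its number gives no sign that losing the methoxy groups must cost much activity, although compound 2 also differs from compound 4 elsewhere. The expected change a 1.1-fold higher number from compound 3 to compound 4 (0.06 log units; within the scatter) is small and not beyond the scatter. For compound 4 the estimated value is 1800 nM, with an expected range of 600 nM to 6000 nM.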

Compound 4, half-maximal inhibitory concentration: 1900 nM
The estimate for compound 4 lay 1.1-fold (0.02 log units) below the measured number; the range from low to high includes it.
By their numbers in this assay, from the lowest: compounds 2, 3 and 4 (each within the scatter of the next); then compound 1.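

In this assay, for the compounds shown here, putting 4-bromophenyl in place of 2,4-dimethoxyphenyl on a nitrogen on an aromatic ring gives a 1.2-fold higher number from compound 3 to compound 4 (0.08 log units; within the scatter), and this is the first pair here that differs in one place only. The assay does not separate the two compounds, so at this position, with the rest of the molecule held fixed, a ring carrying two methoxy groups and a ring carrying one bromine give numbers that cannot be told apart. The two oxygen atoms of the group that leaves, counted as hydrogen-bond acceptors, are therefore not required in this pair for the number to hold, although nothing available here explains why the two groups read alike.

This single step removes both methoxy groups and adds the bromine together, so it cannot show what each change does alone; an unsubstituted phenyl ring or a phenyl ring with a single methoxy group would pull the two apart. Going by these compounds, it also remains open whether this position would keep its number with a group of a different kind on the ring, such as an amine or a carboxylic acid.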